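Swapping the Amide Aryl Group: From Fluorophenyl to Indolyl

The source may report more compounds than this note shows. Statements on the series, on what has been measured and on what is new or still open speak of the compounds shown alone.

Three measured compounds share one core and differ only in the group carried on the amide carbonyl. Compound 1 `CCN1CCN(c2cc(C)c3cc(NC(=O)c4ccccc4F)ccc3n2)CC1` carries a 2-fluorophenyl group; in a functional assay on SK-BR-3 cells (Homo sapiens) for antiproliferative activity, read by MTT assay, with a stated time of 72 h (on this read-out lower numbers stand for stronger inhibition and higher numbers for weaker inhibition), compound 1 gives 38100 nM, the highest number of the three. Compound 2 `CCN1CCN(c2cc(C)c3cc(NC(=O)c4ccc(Cl)cc4)ccc3n2)CC1` carries a 4-chlorophenyl group, and in this assay compound 2 gives 3020 nM. Compound 3 `CCN1CCN(c2cc(C)c3cc(NC(=O)c4ccc[nH]4)ccc3n2)CC1` carries a 1H-pyrrol-2-yl group, and in this assay compound 3 gives 13200 nM. The measured steps are these: a 13-fold lower number from compound 1 to compound 2 (1.10 log units; beyond the scatter); a 2.9-fold lower number from compound 1 to compound 3 (0.46 log units; beyond the scatter); and a 4.4-fold higher number from compound 2 to compound 3 (0.64 log units; beyond the scatter). Every replacement of the 2-fluorophenyl group tried so far has lowered the number beyond the scatter.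

Compound 4 `CCN1CCN(c2cc(C)c3cc(NC(=O)c4cc5ccccc5[nH]4)ccc3n2)CC1` has not yet been measured. The change from compound 1 is 1H-indol-2-yl in place of 2-fluorophenyl on a carbonyl carbon. The step to compound 3 bears most directly on it, since the entering group also holds a five-membered aromatic ring with one hetero atom and one hydrogen-bond donor, and the step to compound 2 shows that a larger lowering is possible. A lowering beyond the scatter is therefore expected, likely between those two steps. Compound 4 is estimated to give 5000 nM, with a range from 1500 nM to 15000 nM. That estimate for compound 4 is expected to mean a 7.6-fold lower number from compound 1 to compound 4 (0.88 log units; beyond the scatter).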

Compound 4, half-maximal inhibitory concentration: 2550 nM
Beside the measured number, compound 4's estimate is 2.0-fold (0.29 log units) above it; low and high end bracket the measured number.
By their numbers in this assay, from the lowest: compounds 4 and 2 (each within the scatter of the next); then compound 3; then compound 1.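

In this assay, the 1H-indol-2-yl group gives a 15-fold lower number from compound 1 to compound 4 (1.17 log units; beyond the scatter), so a hetero-atom-containing group on the carbonyl carbon can match the large drop first seen with a chlorinated phenyl ring, which compound 3 alone had not shown. The comparison with compound 3 is the most informative new reading: the 1H-indol-2-yl group holds a five-membered aromatic ring with one hetero atom plus a six-membered aromatic ring of carbon only, and extending the 1H-pyrrol-2-yl group in this way gives a 5.2-fold lower number from compound 3 to compound 4 (0.71 log units; beyond the scatter). The two best groups here are also quite different in make-up, yet they give a 1.2-fold lower number from compound 2 to compound 4 (0.07 log units; within the scatter), so this position does not depend on one particular type of aryl group among the four compared.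

No measurement here explains why these groups differ, so the reason for these steps remains unknown. The compounds shown leave open whether the hydrogen on the ring nitrogen of compound 4 matters, which a 1-methyl-1H-indol-2-yl group could test, and whether an unsubstituted phenyl group would behave more like compound 1 or compound 2.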